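Turning one stereocentre in compound 2

The source may hold more compounds than are shown below. What is called first, only, known or untested is meant among the compounds shown, and "the series" means these compounds.

compound 1 `Cc1cc(C)c(CN2CCc3c(Cl)cc(-c4c(C)noc4C)c(Cl)c3C2=O)c(=O)[nH]1`: 23 nM
compound 2 `Cc1cc(C)c(CN2CCc3c(Cl)cc([C@H](C)CO)c(Cl)c3C2=O)c(=O)[nH]1`: 186 nM

In a functional assay on KARPAS-422 cells (Homo sapiens) for antiproliferative activity, read by resazurin assay, with a stated time of 72 h (on this read-out lower numbers stand for stronger inhibition and higher numbers for weaker inhibition), compound 2 has the higher number of the two, at 186 nM. Compound 3 `Cc1cc(C)c(CN2CCc3c(Cl)cc([C@@H](C)CO)c(Cl)c3C2=O)c(=O)[nH]1` keeps its atoms and bonds: the two compounds have the same atoms and bonds and differ only in configuration as drawn: 1 of 1 stereo elements differ; a stereocentre at a saturated chain carbon is drawn S in compound 2 and R in compound 3. Going by the values given here, the one measured step, an 8.1-fold higher number from compound 1 to compound 2 (0.91 log units; beyond the scatter), exchanged a whole group rather than a configuration, so it offers only weak guidance. Among the compounds with values here, no pair differing solely in configuration has been measured, so no direction can be argued, although a real shift either way remains possible. The expected change in this assay is a 1.0-fold lower number from compound 2 to compound 3 (0.01 log units; within the scatter), with none beyond the scatter expected. Compound 3 is estimated at 180 nM, within a range of 40 nM to 800 nM.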

Compound 3, half-maximal inhibitory concentration in the KARPAS-422 assay: 1500 nM
Compound 3: middle estimate off by 8.3-fold (0.92 log units), on the low side; the measured number lies above the stated range.
By their numbers in the KARPAS-422 assay, from the lowest: compound 1; then compound 2; then compound 3.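

In the KARPAS-422 assay this position responds to configuration, not only to which group sits there: compound 2 gives 186 nM and compound 3 gives 1500 nM. In the KARPAS-422 assay that is an 8.1-fold higher number from compound 2 to compound 3 (0.91 log units; beyond the scatter), with nothing added or removed. That gap comes down to one difference: the fact that compounds 2 and 3 differ only in the configuration as drawn. In a physicochemical assay for lipophilicity, at pH 7.4 (on this read-out higher numbers stand for higher lipophilicity and lower numbers for lower lipophilicity), compound 2 gives 2.6 and compound 3 gives 2.5. In the physicochemical assay the same pair shows a number 0.10 log units lower from compound 2 to compound 3 (within the scatter), while in the KARPAS-422 assay exchanging 3,5-dimethyl-1,2-oxazol-4-yl for the R form gives a 65-fold higher number from compound 1 to compound 3 (1.81 log units; beyond the scatter).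

What makes the S form the better of the two stays unexplained. As far as these compounds go, it is also open whether the preference for S would hold with an amine or a carboxylic acid in place of the hydroxyl, or with a longer chain.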